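Fluoro for Methyl on the Phenyl Ring of Compound 3

This account rests on a few compounds, and the source may have more. Where it says the series, first, only, none or still open, it means among the compounds named here.

Compound 1 `O=c1[nH]cc(S(=O)(=O)Nc2ccccc2-c2cn(-c3ccccc3)nn2)c(=O)[nH]1`, compound 2 `O=c1[nH]cc(S(=O)(=O)Nc2ccccc2-c2cn(-c3cccc(F)c3)nn2)c(=O)[nH]1` and compound 3 `Cc1ccccc1-n1cc(-c2cccc(NS(=O)(=O)c3c[nH]c(=O)[nH]c3=O)c2)nn1` were measured in a functional assay on HepG2 cells (Homo sapiens) for antiproliferative activity, read by MTT assay, with a stated time of 24 h; a higher number here means a weaker inhibitor, a lower number a stronger inhibitor. Compound 1 gives 6160 nM. Compound 2 reaches only the limit > 20000 nM. Compound 3 gives 9570 nM, the highest of the two numbers, though its gap to compound 1 lies within the scatter.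

Compound 4 `O=c1[nH]cc(S(=O)(=O)Nc2cccc(-c3cn(-c4ccccc4F)nn3)c2)c(=O)[nH]1` differs from compound 3 by fluoro in place of methyl on an aromatic carbon. Among the measured compounds shown here, the only measured step with fluorine entering an aromatic ring, an at least 3.2-fold higher number from compound 1 to compound 2 (0.51 log units; beyond the scatter), bears on this in part, since there fluoro replaces hydrogen rather than methyl, and it ended at the limit (the limit of > 20000 nM in this assay, at which 1 of the 3 values shown sits). A modest rise, a 1.4-fold higher number from compound 3 to compound 4 (0.13 log units; within the scatter), is therefore expected. Compound 4 is estimated at 13000 nM, between 5000 nM and 30000 nM.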

Compound 4, half-maximal inhibitory concentration: 13900 nM
Beside the measured number, compound 4's estimate is 1.1-fold (0.03 log units) below it; measured number inside the range.
By their numbers in this assay, from the lowest: compounds 1, 3 and 4 (each within the scatter of the next, the first and the last beyond it). At a limit, above all of these: compound 2.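

In this assay, the exchange of 2-methylphenyl for 2-fluorophenyl, on the aromatic carbon ortho to a large group, gives a 1.5-fold higher number from compound 3 to compound 4 (0.16 log units; within the scatter), so the two groups cannot be told apart at this position. Compound 4 still gives a measured number and does not reach the limit of this assay: the limit of > 20000 nM in this assay, at which 1 of the 4 values shown sits.

As far as these compounds go, whether a chloro group, a methoxy group or an amine on this carbon would also stay within the scatter of compound 3 remains open. So does whether the same exchange would read alike on the core of compound 1.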